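This account rests on a few compounds, and the source may have more. Where it says the series, first, only, none or still open, it means among the compounds named here.

Measured so far in a functional assay on MCF7 cells (Homo sapiens) for cytotoxicity, read by MTT assay, with a stated time of 72 h; a lower number here means a stronger inhibitor, a higher number a weaker inhibitor:
- compound 1 `Cc1cc(=O)n(-c2ccc(Br)cc2F)nc1C(=O)Nc1ccc(Oc2ncnc3ccsc23)cc1` gives 9360 nM
- compound 2 `Cc1cc(=O)n(-c2ccccc2OC(F)(F)F)nc1C(=O)Nc1ccc(Oc2ncnc3ccsc23)cc1` gives 23800 nM

Going by the values given here, compound 2 carries the highest of the two numbers; its nearest neighbour is compound 1, and the step of a 2.5-fold higher number from compound 1 to compound 2 (0.41 log units; beyond the scatter) is the only measured step. That step exchanges the aryl group on the aromatic nitrogen of the shared core and moves the number by a modest amount, beyond the scatter.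

Compound 3 `Cc1cc(=O)n(-c2cccc(F)c2)nc1C(=O)Nc1ccc(Oc2ncnc3ccsc23)cc1` is not yet measured in this assay. It differs from compound 2 at the same position: 3-fluorophenyl in place of 2-(trifluoromethoxy)phenyl on an aromatic nitrogen. The step from compound 1 to compound 2 is the one that bears on this change, since it also replaces the aryl group next to the ring nitrogen, and it was modest in size. A change of similar or smaller size is therefore expected, and the direction is uncertain; a return toward the number of compound 1 is as plausible as no change beyond the scatter. The estimate for compound 3 is 13000 nM (range 5000 nM to 32000 nM), which would mean a step of a 1.8-fold lower number from compound 2 to compound 3 (0.26 log units; within the scatter).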

Compound 3, half-maximal inhibitory concentration: 6410 nM
For compound 3 the middle estimate is 2.0-fold (0.31 log units) above the measured one; the measured number falls inside the stated range.
By their numbers in this assay, from the lowest: compounds 3 and 1 (each within the scatter of the next); then compound 2.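

Across the aryl groups on the aromatic nitrogen of the shared core, compound 2 now stands apart from two different partners rather than one: in this assay the exchange of 2-(trifluoromethoxy)phenyl for 3-fluorophenyl gives a 3.7-fold lower number from compound 2 to compound 3 (0.57 log units; beyond the scatter), the second step beyond the scatter that leaves this group. The two fluorine-bearing aryl groups cannot be told apart here, as the step of a 1.5-fold lower number from compound 1 to compound 3 (0.16 log units; within the scatter) shows, so the bromine of compound 1 and its second fluorine make no readable difference in this comparison. With three compounds, the series therefore reads as one group of two plus compound 2, and nothing measured here accounts for that split.

Compound 2 and compound 3 differ both in the substituent and in where it sits on the phenyl ring, so the compounds shown do not separate these two changes. Also open, going by these compounds, is whether an aryl group carrying an amine or a carboxylic acid, or a longer alkyl chain in place of the aryl group, would stay with compound 1 and compound 3 or move away from them.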